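A few compounds are considered here, and "the series" means these few. Any claim that something is new, unique, unknown or untested is made for them only; others in the source may bear on it.

Measured compounds:
Compound 1, `COc1cc(/C=C/C(=O)c2sc(Nc3ccc(F)c(Cl)c3)nc2C)cc(OC)c1OC`, gives 6310 nM in a functional assay on NCI-H460 cells (Homo sapiens) for cytotoxicity, read by MTT assay; a lower number here means a stronger inhibitor, a higher number a weaker inhibitor.
Compound 2, `Cc1ccc(Nc2nc(C)c(C(=O)/C=C/c3ccccc3)s2)cc1`, gives in this assay only a limit of the assay, > 25000 nM.

Among the compounds with values here, compound 1 therefore stands as the only compound with a numerical value in this assay; the other result is a limit, and one of the two values sits there (the limit of > 25000 nM in this assay, at which 1 of the 2 values shown sits). Within the data shown here, compound 2 differs from compound 1 in more than one place, so the two values together show only that compound 1 gives a number and compound 2 does not.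

The unmeasured compound 3, `COc1cc(/C=C/C(=O)c2sc(Nc3cccc(C)c3)nc2C)cc(OC)c1OC`, keeps the core of compound 1 and changes one group: 3-methylphenyl in place of 3-chloro-4-fluorophenyl on a nitrogen on an aromatic ring. Among the measured compounds shown here, no measured pair covers this change on its own, so the size of the step rests on expectation alone. For the measured compounds named here, the halogen-bearing ring of compound 1 is the only variant with a number, while a methylphenyl appears only in compound 2, which reached the limit. A moderate loss of potency in this assay is expected, a 1.9-fold higher number from compound 1 to compound 3 (0.28 log units; within the scatter). Compound 3 is estimated at 12000 nM, within a range of 4000 nM to 40000 nM.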

Compound 3, half-maximal inhibitory concentration: 19800 nM
Estimate against measurement, compound 3: 1.7-fold (0.22 log units) below; the range from low to high includes it.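

With the shared core held fixed, the group on the nitrogen makes a measurable difference in this assay: placing 3-methylphenyl where 3-chloro-4-fluorophenyl stood gives a 3.1-fold higher number from compound 1 to compound 3 (0.50 log units; beyond the scatter), a modest step that still lies beyond the scatter. The change does not remove activity from the range the assay can read, since compound 3 still gives a number, 19800 nM. Compound 2 differs from compound 1 in more than one place and gives only a limit, so it adds nothing to the size of this step: the limit of > 25000 nM in this assay, at which 1 of the 3 values shown sits.

This single step swaps the chlorine, the fluorine and the methyl all at once, so it cannot show which of them accounts for the difference. Also open, from the compounds shown here alone, is how a 3-chlorophenyl, a 4-fluorophenyl or a ring carrying an amine or a carboxylic acid would read on this nitrogen.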